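Swapping an aryl amine for a benzylamine on a shared core

This account rests on a few compounds, and the source may have more. Where it says the series, first, only, none or still open, it means among the compounds named here.

Measured compounds:
compound 1, `CCc1ccc(NC2=CC(=O)c3c(nc4n3[C@H]3OC[C@@H](O)[C@H]3OC4)C2=O)cc1`: 1110 nM
compound 2, `Cc1ccc(NC2=CC(=O)c3nc4n(c3C2=O)[C@H]2OC[C@@H](O)[C@H]2OC4)cc1C`: 860 nM

In a functional assay on MGC-803 cells (Homo sapiens) for inhibition, read by sulforhodamine B assay (a higher number here means a weaker inhibitor, a lower number a stronger inhibitor), compound 1 gives 1110 nM, and compound 2 gives 860 nM. These two numbers sit within the usual scatter of each other, so neither compound stands apart from the other. Compound 3, `O=C1C(NCc2ccccc2)=CC(=O)c2c1nc1n2[C@H]2OC[C@@H](O)[C@H]2OC1`, has not yet been measured in this assay. Compared with compound 1, it carries benzyl in place of 4-ethylphenyl on an amine nitrogen. Among the measured compounds shown here, no measured pair shows what this change does, so the step from compound 1 is expected to be modest, with some lean toward a weaker inhibitor: a 1.8-fold higher number from compound 1 to compound 3 (0.26 log units; within the scatter). Compound 3 is therefore estimated at 2000 nM, with a range from 600 nM to 7000 nM.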

Compound 3, half-maximal inhibitory concentration: 3490 nM
Compound 3: middle estimate off by 1.7-fold (0.24 log units), on the low side; low and high end bracket the measured number.
By their numbers in this assay, from the lowest: compounds 2 and 1 (each within the scatter of the next); then compound 3.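

In this assay, among the compounds shown here, benzyl in place of 4-ethylphenyl on the amine nitrogen gives a 3.1-fold higher number from compound 1 to compound 3 (0.50 log units; beyond the scatter), the first step that lies beyond the scatter. This position is therefore sensitive to the group it carries, even though both groups hold one six-membered aromatic ring of carbon only. No measurement at hand gives a reason for this step. Still open, from the compounds shown here alone, is whether a plain phenyl or an ethyl-bearing benzyl on this nitrogen would read closer to compound 1 or compound 3. Going by these compounds, the effect of a cyclohexyl group or a longer alkyl chain there is also open.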